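Swapping a chlorophenyl for a fluoromethylphenyl on the core

The compounds below may be only part of what the source reports. "The series", "measured", "known", "first", "only" and "open" are said of these compounds alone.

Compound 2 `CC(C(=O)NCc1ccc(C(F)(F)F)nc1-c1cccc(Cl)c1)c1ccc(NS(C)(=O)=O)c(F)c1` is one of three related compounds tested in an assay on CHO cells for antagonist activity at transient receptor potential cation channel subfamily V member 1 (Homo sapiens), read by FLIPR; on this read-out lower numbers stand for stronger inhibition and higher numbers for weaker inhibition. Compound 2 gives 0.5 nM. Compound 3 `CC(C(=O)NCc1ccc(C(F)(F)F)nc1-c1ccc(C(C)(C)C)cc1)c1ccc(NS(C)(=O)=O)c(F)c1` gives 0.5 nM, so compounds 2 and 3 sit together at the low end of the three numbers, with no change at the digits printed from compound 2 to compound 3 (within the scatter). Compound 1 `CC(C(=O)NCc1ccc(C(F)(F)F)nc1-c1ccccc1)c1ccc(NS(C)(=O)=O)c(F)c1`, which carries a bare phenyl at the same position, gives 6.4 nM; from there, a 13-fold lower number from compound 1 to compound 2 (1.11 log units; beyond the scatter) and a 13-fold lower number from compound 1 to compound 3 (1.11 log units; beyond the scatter) show that putting a group on that phenyl gave much lower numbers in both cases.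

Compound 4 `Cc1cc(-c2nc(C(F)(F)F)ccc2CNC(=O)C(C)c2ccc(NS(C)(=O)=O)c(F)c2)ccc1F` has not yet been measured. It differs from compound 2 in one place: 4-fluoro-3-methylphenyl in place of 3-chlorophenyl on an aromatic carbon. The measured steps bear on this only indirectly: both show a phenyl carrying a group giving a lower number than the bare phenyl of compound 1, while two quite different groups on that phenyl gave the same number in compounds 2 and 3. The expected step is a 1.6-fold higher number from compound 2 to compound 4 (0.20 log units; within the scatter) in this assay, within the scatter. Compound 4 is estimated at 0.8 nM, with a range from 0.2 nM to 3 nM.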

Compound 4, inhibition constant: 0.4 nM
Compound 4: the middle estimate sits 2.0-fold (0.30 log units) above what was measured, and the stated range covers the measured number.
By their numbers in this assay, from the lowest: compounds 4, 2 and 3 (each within the scatter of the next); then compound 1.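

In this assay, a 1.3-fold lower number from compound 2 to compound 4 (0.10 log units; within the scatter) and a 1.3-fold lower number from compound 3 to compound 4 (0.10 log units; within the scatter) place a third substituted phenyl level with the first two, this time one that carries two groups, a fluoro and a methyl, where compounds 2 and 3 carry one each. With a 16-fold lower number from compound 1 to compound 4 (1.20 log units; beyond the scatter) standing beside the earlier steps, all three substituted phenyls shown now sit apart from the bare phenyl of compound 1, and none of them goes against that pattern. No measurement here explains why such different groups give such similar numbers.

The three numbers lie too close together to rank the chloro, tert-butyl, fluoro and methyl groups against one another. On these data alone, whether the pattern extends to an amine or a carboxylic acid on this phenyl, or to a cyclohexyl ring in its place, remains open.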